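Dichlorophenyl Replaces Pyridin-3-yl: Cytotoxicity Expected Unchanged

This account rests on a few compounds, and the source may have more. Where it says the series, first, only, none or still open, it means among the compounds named here.

Compound 3, `CCOC(=O)CCCCCOc1cccc(CN(C(=O)c2ccc(-c3cccnc3)cc2)C(C)C)c1`, carries a pyridin-3-yl group on the shared core. In an ADME assay on HEK293 cells (Homo sapiens) for cytotoxicity, read by CellTiter-Glo and resazurin assay, with a stated time of 72 h (on this read-out lower numbers stand for an effect already at smaller amounts and higher numbers for an effect only at larger amounts of compound), compound 3 gives > 26000 nM, which is a limit of the assay rather than a number. Two related compounds stand beside it. Compound 1, `COc1cccc(-c2ccc(C(=O)N(Cc3cccc(OCCCCCC(=O)O)c3)C(C)C)cc2)c1`, gives > 20900 nM in this assay, again a limit. Compound 2, `CC(C)N(Cc1cccc(OCCCCCC(=O)O)c1)C(=O)c1ccc(-c2cccc(Cl)c2)cc1`, gives > 21900 nM in this assay, also a limit. The step that the two limits leave unreadable from compound 1 to compound 2 therefore cannot be sized, since both ends sit at a limit. Compound 4, `CCOC(=O)CCCCCOc1cccc(CN(C(=O)c2ccc(-c3ccc(Cl)c(Cl)c3)cc2)C(C)C)c1`, differs from compound 3 in one place: 3,4-dichlorophenyl in place of pyridin-3-yl on an aromatic carbon. No measured step covers this exchange, and the only guidance is that every value so far sits at a limit, as shown by the limit of > 20900 nM in this assay, at which 1 of the 3 values shown sits, the limit of > 21900 nM in this assay, at which 1 of the 3 values shown sits, and (the limit of > 26000 nM in this assay, at which 1 of the 3 values shown sits). For compound 4 the expectation is accordingly no movement beyond the usual scatter, with the result most likely reported as a limit once more. The expected step is a step that the limit leaves unreadable from compound 3 to compound 4, small and of no clear direction. Compound 4 is expected to give about 30000 nM in this assay, within a range from 12000 nM to 70000 nM.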

Compound 4, half-maximal effective concentration: > 26000 nM
Compound 4 was reported as a limit (the forecaster's own chance of this, stated with the estimate: 80%); the middle value is on the limit's open side.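

In this assay compound 4 gives > 26000 nM, which is a limit and not a number. Among these compounds, compound 3 also sits at a limit, so no step from compound 3 to compound 4 can be read. The compounds shown leave open at what concentration any of them would show an effect in this assay, and whether the groups exchanged on the shared core would change it.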